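Bulkier group on the fused core: compound 3 expected

The compounds below may be only part of what the source reports. "The series", "measured", "known", "first", "only" and "open" are said of these compounds alone.

Compound 2 `CS(=O)(=O)N1CCN(CC(O)CN2CCC(CNC(=O)c3cccc4[nH]c(C5CC5)nc34)CC2)CC1` was tested in an assay on isolated protein for binding affinity to 5-hydroxytryptamine receptor 3A (Homo sapiens) (on this read-out higher numbers stand for weaker inhibition and lower numbers for stronger inhibition), and gave 50100 nM. Compound 1 `CCc1nc2c(C(=O)NCC3CCN(CC(O)CN4CCN(S(C)(=O)=O)CC4)CC3)cccc2[nH]1` gave 79400 nM in this assay, so compound 2 holds the lowest of the two numbers, though the gap to compound 1 is within the usual scatter. Compound 3 `CC(C)(C)c1nc2c(C(=O)NCC3CCN(CC(O)CN4CCN(S(C)(=O)=O)CC4)CC3)cccc2[nH]1` has not yet been measured. It differs from compound 2 in one place: tert-butyl in place of cyclopropyl on an aromatic carbon. Among the compounds with values here, the only measured step touching this position is the change from ethyl to cyclopropyl, which moved the number by a 1.6-fold lower number from compound 1 to compound 2 (0.20 log units; within the scatter), an amount within the scatter. Because the earlier swap at this position gave a 1.6-fold lower number from compound 1 to compound 2 (0.20 log units; within the scatter), the further enlargement to tert-butyl is expected to leave the number close to where compound 2 stands, with no step beyond the scatter. The expected step is therefore a 1.2-fold higher number from compound 2 to compound 3 (0.08 log units; within the scatter). Compound 3 is estimated at 60000 nM, with a likely range from 20000 nM to 200000 nM.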

Compound 3, inhibition constant: 39800 nM
For compound 3 the middle estimate is 1.5-fold (0.18 log units) above the measured one; the measured number falls inside the stated range.
By their numbers in this assay, from the lowest: compounds 3, 2 and 1 (each within the scatter of the next).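

In this assay tert-butyl in place of cyclopropyl gives a 1.3-fold lower number from compound 2 to compound 3 (0.10 log units; within the scatter) and tert-butyl in place of ethyl gives a 2.0-fold lower number from compound 1 to compound 3 (0.30 log units; within the scatter) at this position. Even the widest step among these three compounds stays within the scatter, so neither adding carbon atoms nor opening the ring of cyclopropyl into the branched tert-butyl separates them on this read-out. No evidence is available to explain this flat result.

All three groups shown at this position are made of carbon only, which leaves open whether an amine, a carboxylic acid or a methoxy group there would move the number beyond the scatter. On these data alone, whether changes elsewhere in the molecule would do so also remains open, as the rest of the structure is the same in all three compounds.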